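The source may hold more compounds than are shown below. What is called first, only, known or untested is meant among the compounds shown, and "the series" means these compounds.

Working notes on the series. Within the data shown here, compound 1 `Cn1cc(-c2nc3c(-c4ccnc(OC5CC5)c4)cnn3cc2OCC(C)(C)O)cn1` gives 53% in an ADME assay on microsomes from liver (Homo sapiens) for metabolic stability, with a stated time of 60 min, tested at 1 uM (on this read-out lower numbers stand for a less stable compound and higher numbers for a more stable compound), and stands highest of the three numbers measured so far. Compound 2 `COc1cc(-c2cnn3cc(OC)c(C(C)C)nc23)ccn1` gives 40% in this assay, a gap to compound 1 that lies beyond the scatter. Compound 3 `COc1cc(-c2cnn3cc(OC)c(C4CCOC4)nc23)ccn1` gives 29% in this assay, the furthest from compound 1, again beyond the scatter. Among the measured compounds shown here, the only measured step between neighbours, a number 11 percentage points lower from compound 2 to compound 3 (beyond the scatter), concerns oxolan-3-yl in place of isopropyl on an aromatic carbon; it is modest in size and shares no feature with the change now in question, so it offers no direct guide.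

Compound 4 `Cn1cc(-c2nc3c(-c4ccnc(OC5CC5)c4)cnn3cc2OCCCC(C)(C)O)cn1` differs from compound 1 in one place: 3-hydroxy-3-methylbutyl in place of 1-hydroxy-1-methylethyl on a saturated chain carbon bound to an oxygen on an aromatic ring. For the measured compounds named here, no pair among the measured compounds tests a lengthening of this chain while the same hydroxy group is kept, so there is no measured step to lean on for direction. In the absence of such a step the expected step of a number 6 percentage points lower from compound 1 to compound 4 (within the scatter) is taken as small, likely within the scatter, but with a wide range allowed on either side to reflect the lack of precedent. Compound 4 is therefore estimated at 47% in this assay, with a range from 27% to 67%.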

Compound 4, percent of the compound remaining: 54%
Estimate against measurement, compound 4: 7 percentage points below; low and high end bracket the measured number.
By their numbers in this assay, from the lowest: compound 3; then compound 2; then compounds 1 and 4 (each within the scatter of the next).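

The chain on a saturated chain carbon bound to an oxygen on an aromatic ring can go from 1-hydroxy-1-methylethyl to 3-hydroxy-3-methylbutyl, from 4 to 6 heavy atoms with the hydroxy group kept, and the step is a number 1 percentage points higher from compound 1 to compound 4 (within the scatter) in this assay. Among these compounds, this gives the first reading at this position, as the earlier step between neighbours concerned a different place, and within this pair the added chain length leaves the read-out inside the scatter. No supporting measurement bears on why the read-out holds across this change.

Going by these compounds, it remains open how far this tolerance extends at the same position, as a still longer chain, or a chain ending in an amine or a carboxylic acid in place of the hydroxy group, could give a different reading. On these data alone, it also remains open whether the step carries over to compounds with the isopropyl group of compound 2 or the oxolan-3-yl group of compound 3, as the present reading rests on a single pair.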